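This account rests on a few compounds, and the source may have more. Where it says the series, first, only, none or still open, it means among the compounds named here.

In a functional assay on MCF7 cells (Homo sapiens) for cytotoxicity, read by MTT assay, with a stated time of 72 h (a lower number here means a stronger inhibitor, a higher number a weaker inhibitor), compound 1 `COc1cc(C=C2C(=O)N(c3ccc(Cl)cc3)N(c3ccc(Cl)cc3)C2=O)ccc1O` gives 22800 nM. Compound 2 `COc1ccc(C=C2C(=O)N(c3ccc(Cl)cc3)N(c3ccc(Cl)cc3)C2=O)cc1` gives > 128000 nM, which is a limit of the assay and not a number. Compound 3 `COc1ccc(C=C2C(=O)N(c3ccc(Cl)cc3)N(c3ccc(Cl)cc3)C2=O)cc1OC` carries methoxy in place of hydrogen on an aromatic carbon of compound 2, ortho to a methoxy group (methoxy in place of hydrogen on an aromatic carbon), turning 4-methoxyphenyl into 3,4-dimethoxyphenyl. For the measured compounds named here, the only measured guide is an at least 5.6-fold higher number from compound 1 to compound 2 (0.74 log units; beyond the scatter), which replaced 4-hydroxy-3-methoxyphenyl with 4-methoxyphenyl. Compound 3 has no hydroxy, as in compound 2, so only a small move toward a lower number is expected in this assay. The expected change is an at least 1.2-fold lower number from compound 2 to compound 3 (0.10 log units; that floor lies within the scatter). The estimate for compound 3 is 100000 nM, with an expected range of 35000 nM to 200000 nM.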

Compound 3, half-maximal inhibitory concentration: > 128000 nM
Compound 3 ended at the assay's limit; the forecaster's own chance of this, stated with the estimate: 50%; middle value at least 1.2-fold (0.10 log units) from the limit.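

Putting a methyl on the hydroxy oxygen, a single change, gives an at least 5.6-fold higher number from compound 1 to compound 3 (0.74 log units; beyond the scatter). Keeping an oxygen at this place is therefore not enough: the 3,4-dimethoxyphenyl group of compound 3 does not match the 4-hydroxy-3-methoxyphenyl group of compound 1. The step from compound 2 to compound 3 cannot be read, because both stop at a limit: the limit of > 128000 nM in this assay, at which 2 of the 3 values shown sit.

From the compounds shown here alone, whether an amine or a carboxylic acid in place of that hydroxy would keep the lower number remains open. So does the true size of the numbers for compound 2 and compound 3.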